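Replacing 4-methylphenyl with cyclohexyl in compound 2

The compounds below may be only part of what the source reports. "The series", "measured", "known", "first", "only" and "open" are said of these compounds alone.

Compound 1 `O=C(Nc1nnc(-c2cccc(O)c2O)s1)c1ccc(Cl)cc1`: 9600 nM
Compound 2 `Cc1ccc(C(=O)Nc2nnc(-c3ccc(O)c(O)c3)s2)cc1`: 10500 nM
Compound 3 `O=C(Nc1nnc(-c2cccc(O)c2O)s1)c1ccccc1`: 20700 nM

In a functional assay on HL-60 cells (Homo sapiens) for cytotoxicity, read by MTT assay, with a stated time of 72 h (on this read-out higher numbers stand for weaker inhibition and lower numbers for stronger inhibition), compound 2 gives 10500 nM, which lies within the scatter of the values of both compound 1 and compound 3. These three compounds therefore span a narrow range, and compound 2 is not separated from either of the others. The next compound, compound 4 `O=C(Nc1nnc(-c2ccc(O)c(O)c2)s1)C1CCCCC1`, keeps the core of compound 2 and carries cyclohexyl in place of 4-methylphenyl on a carbonyl carbon. The change thus swaps one six-membered aromatic ring of carbon only for one six-membered non-aromatic ring of carbon only.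

Among the compounds with values here, no measured compound has a non-aromatic ring in this place, so the data do not show directly what this exchange does. Within the data shown here, only one measured step offers a loose guide: a 2.2-fold higher number from compound 1 to compound 3 (0.33 log units; beyond the scatter), with hydrogen in place of chloro on an aromatic carbon. That step is modest, although beyond the scatter, and it alters a substituent on the ring and leaves the ring itself in place. On this thin evidence, no large change is expected in this assay.

The expected step is a 1.4-fold higher number from compound 2 to compound 4 (0.15 log units; within the scatter), an estimate that stays within the scatter. For compound 4 the estimated value is 15000 nM, with an expected range of 6000 nM to 40000 nM.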

Compound 4, half-maximal inhibitory concentration: 8800 nM
Compound 4: the middle estimate sits 1.7-fold (0.23 log units) above what was measured, and the stated range covers the measured number.
By their numbers in this assay, from the lowest: compounds 4, 1, 2 and 3 (each within the scatter of the next, the first and the last beyond it).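

Within the data shown here, compound 4 gives the first direct reading of a non-aromatic ring on this carbonyl carbon, and in this assay the exchange amounts to a 1.2-fold lower number from compound 2 to compound 4 (0.08 log units; within the scatter). On the core of compound 2, an aromatic ring at this place is therefore not required to keep the number within the scatter: 4-methylphenyl and cyclohexyl cannot be told apart here, although they differ in ring type and in heavy-atom count. The data offer no explanation for this outcome, and nothing shown accounts for why the two groups read alike.

What the compounds shown leave open is how far this tolerance extends, as a longer chain, an amine or a carboxylic acid on the same carbonyl carbon could behave quite differently from either ring. They also leave open whether cyclohexyl would read the same on the core of compound 1, and whether a result from these cells, which reports cytotoxicity alone, would carry over to any other read-out.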